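One More Methoxy to Hydroxy Swap

A few compounds are considered here, and "the series" means these few. Any claim that something is new, unique, unknown or untested is made for them only; others in the source may bear on it.

In a physicochemical assay, read by spectrophotometry, with a stated time of 6 min (on this read-out lower numbers stand for stronger inhibition and higher numbers for weaker inhibition), compound 1 `COc1cc(/C=N/NC(=O)CCc2nc3ccccc3c(=O)[nH]2)cc(OC)c1OC` gives 55000000 nM and compound 2 `COc1cc(/C=N/NC(=O)CCCc2nc3ccccc3c(=O)[nH]2)cc(OC)c1OC` gives 60000000 nM as its reading. Compound 3 `COc1cc(/C=N/NC(=O)CCc2nc3ccccc3c(=O)[nH]2)cc(OC)c1O` gives 105000000 nM and so lies within the scatter of both other compounds, which leaves no real order among the three.

Compound 4 `COc1cc(/C=N/NC(=O)CCc2nc3ccccc3c(=O)[nH]2)cc(O)c1O` has not been measured yet. It differs from compound 3 by a single change hydrogen in place of methyl on an oxygen on an aromatic ring in which hydrogen takes the place of methyl on an oxygen on an aromatic ring, that is, methoxy to hydroxy. The same swap has been measured only once, and that step was small (a 1.9-fold higher number from compound 1 to compound 3 (0.28 log units; within the scatter)). One step is thin evidence, but it gives no ground to expect a move beyond the scatter in this assay and, if anything, points toward a slightly higher number. The expected size of the new step is small (a 1.3-fold higher number from compound 3 to compound 4 (0.12 log units; within the scatter)). For compound 4 the estimated value is 140000000 nM (expected range 50000000 nM to 280000000 nM).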

Compound 4, half-maximal inhibitory concentration: 40000000 nM
Compound 4: the middle estimate sits 3.5-fold (0.54 log units) above what was measured; the whole stated range lies above it.
By their numbers in this assay, from the lowest: compounds 4, 1, 2 and 3 (each within the scatter of the next, the first and the last beyond it).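

Within the data shown here, the same methoxy to hydroxy change, made at a different oxygen on the aromatic ring, now gives in this assay a step of a 2.6-fold lower number from compound 3 to compound 4 (0.42 log units; beyond the scatter) and so moves the reading clearly for the first time. Its direction is opposite to that of the earlier step of a 1.9-fold higher number from compound 1 to compound 3 (0.28 log units; within the scatter), so the outcome of this change depends on which oxygen carries it, at least across these two steps, although the earlier step alone stays within the scatter. Nothing available explains why the two steps differ.

Two steps are too few to show whether the hydroxy itself matters or whether simply losing the methyl is enough. Also open, on these data alone, is how an ethyl on this oxygen, or an amine on the aromatic ring in place of the hydroxy, would read.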